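The source may hold more compounds than are shown below. What is called first, only, known or untested is meant among the compounds shown, and "the series" means these compounds.

The measured compounds:

Compound 1 `CC(C)c1nccc2nn(-c3ccccc3)cc12` gives 98800 nM in a functional assay on MCF7 cells (Homo sapiens) for inhibition, read by fluorescence, with a stated time of 72 h; on this read-out lower numbers stand for stronger inhibition of growth and higher numbers for weaker inhibition of growth.
Compound 2 `CCCCCc1cc2nn(-c3ccccc3)cc2cn1` gives 11800 nM in this assay.
Compound 3 `CCCCc1cc2nn(-c3ccccc3)cc2cn1` gives 13300 nM in this assay.

Among these three, compound 2 stands at the lowest number, with compound 3 nearest and compound 1 furthest; the gap from compound 2 up to compound 1 lies beyond the usual scatter, while compound 3 sits within it. For the measured compounds named here, only one single-point step is available among the measured compounds: a 1.1-fold higher number from compound 2 to compound 3 (0.05 log units; within the scatter), which concerns the saturated chain and not the ring.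

Compound 4 `CCCCCc1cc2nn(-c3ccccc3)cc2c(C)n1` differs from compound 2 by methyl in place of hydrogen on an aromatic carbon. Going by the values given here, no measured step touches this aromatic carbon of the shared core; the one step known, a 1.1-fold higher number from compound 2 to compound 3 (0.05 log units; within the scatter), bears on the pentyl group rather than on the ring, and it lies within the scatter. Among the compounds with values here, the values of compound 1 and compound 2 differ in more than one place and give no single step to borrow. With nothing pointing either way, the expectation for compound 4 is a number close to that of compound 2, so that a 1.0-fold higher number from compound 2 to compound 4 (0.01 log units; within the scatter) is expected to stay within the scatter. The estimate for compound 4 is 12000 nM, with a range from 4000 nM to 36000 nM to allow for a change at an unmeasured place.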

Compound 4, concentration for 50% growth inhibition: 17000 nM
For compound 4 the middle estimate is 1.4-fold (0.15 log units) below the measured one; measured number inside the range.
By their numbers in this assay, from the lowest: compounds 2, 3 and 4 (each within the scatter of the next); then compound 1.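

For the compounds shown here, the step of methyl in place of hydrogen gives a 1.4-fold higher number from compound 2 to compound 4 (0.16 log units; within the scatter) in this assay, and it is the first reading on an aromatic carbon of the shared core, as the earlier step concerned only the saturated chain. Compound 2 and compound 4 therefore cannot be told apart on this read-out, so this carbon, next to the ring nitrogen and meta to a pentyl group, carries a methyl without a step beyond the scatter. Nothing available bears on how this result comes about.

The compounds shown leave open whether a different group on this aromatic carbon, such as an amine, a methoxy group, a carboxylic acid or a phenyl ring, would also stay within the scatter of compound 2. Going by these compounds, it also remains open whether the same methyl would read alike on the shorter chain of compound 3 or with a longer chain in place of the pentyl group, as a single step at one place cannot show whether the two places act independently.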